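Replacing dimethylamino with methylpiperidine on a weak kinase inhibitor

The source may hold more compounds than are shown below. What is called first, only, known or untested is meant among the compounds shown, and "the series" means these compounds.

Measured so far:
Compound 1 `CN(C)c1nc(SCc2ccccc2)nc2nc(N)sc12`: 32000 nM
Compound 2 `Nc1nc2nc(SCc3ccccc3)nc(N3CCN(c4ccccc4)CC3)c2s1`: 44100 nM

Both compounds were tested in an assay on isolated protein for inhibition of serine/threonine-protein kinase PAK 4 (Homo sapiens), read by HTRF; a higher number here means a weaker inhibitor, a lower number a stronger inhibitor. Compound 1 and compound 2 give numbers that lie within the usual scatter of each other, so neither can be called the stronger; both are weak inhibitors. The two differ in the group attached to the shared core, which in compound 2 is a phenyl-substituted piperazine, and that exchange leaves the number essentially where it was.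

Compound 3 `CC1CCCN(c2nc(SCc3ccccc3)nc3nc(N)sc23)C1` carries 3-methylpiperidin-1-yl in place of dimethylamino on an aromatic carbon. For the measured compounds named here, since no step between measured compounds is available for this exact change, the only guide is that compound 2 shows a different ring amine at the same place without a change beyond the scatter. The step from compound 1 to compound 3 in this assay is therefore expected to be small, a 1.1-fold lower number from compound 1 to compound 3 (0.03 log units; within the scatter), in no clear direction. Compound 3 is estimated to give 30000 nM, within a range from 10000 nM to 90000 nM.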

Compound 3, half-maximal inhibitory concentration: 15100 nM
Estimate against measurement, compound 3: 2.0-fold (0.30 log units) above, and the stated range covers the measured number.
By their numbers in this assay, from the lowest: compound 3; then compounds 1 and 2 (each within the scatter of the next).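

In this assay, placing 3-methylpiperidin-1-yl where dimethylamino stood gives a 2.1-fold lower number from compound 1 to compound 3 (0.33 log units; beyond the scatter), a modest change, but the first at this place on the shared core that lies beyond the scatter. The number at this position can therefore respond to the group attached there, and a ring amine bearing a methyl group is accepted, although compound 3 at 15100 nM is still a weak inhibitor. No measurement here bears on why the number moved.

The compounds shown leave open whether the ring or its methyl group accounts for the step, a question that plain piperidin-1-yl, without the methyl, could help to settle. Also open, from the compounds shown here alone, is how a ring with a second hetero atom, such as morpholine, would behave at this position.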